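The source may report more compounds than this note shows. Statements on the series, on what has been measured and on what is new or still open speak of the compounds shown alone.

Three esters of the same dimethylaminopropanol core have been examined in an assay on NIH3T3 cells with Urotensin-2 receptor (Homo sapiens) as the target; on this read-out lower numbers stand for smaller maximal responses and higher numbers for larger maximal responses. Compound 1, `CN(C)CCC(OC(=O)c1ccc(-c2ccccc2)cc1)c1ccc(Cl)cc1`, carries a phenyl on its benzoate ring; in this assay compound 1 reaches 53%. Compound 2, `COc1cccc(C(=O)OC(CCN(C)C)c2ccc(Cl)cc2)c1C`, gives 88% in this assay, and compound 3, `Cc1cc(C)c(C(=O)OC(CCN(C)C)c2ccc(Cl)cc2)cc1C`, gives 60%. Of the three numbers, compound 1 stands at the low end: compound 3 lies within the usual scatter of it, so no order between these two can be read, whereas compound 2 lies well beyond the scatter and higher.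

The unmeasured compound 4, `Cc1ccc(C(=O)OC(CCN(C)C)c2ccc(Cl)cc2)cc1`, differs from compound 1 in one place: methyl in place of phenyl on an aromatic carbon. The change sits on an aromatic carbon of a six-membered aromatic ring of carbon only, para to a large group.

Among the compounds with values here, no pair of measured compounds shows this exact change, so nothing is known directly of its size. Compound 3, which carries only methyl groups on the same ring, gives 60%, and compound 2 gives 88%; both lie above the number of compound 1. A small upward step is therefore expected, of about a number 12 percentage points higher from compound 1 to compound 4 (beyond the scatter), close to the edge of the scatter. For compound 4 a response of 65% is estimated in this assay, with a range from 45% to 85%.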

Compound 4, largest response reached (reported as efficacy), in percent of the reference or control that the assay uses: 56%
Compound 4: the middle estimate sits 9 percentage points above what was measured; the range from low to high includes it.
By their numbers in this assay, from the lowest: compounds 1, 4 and 3 (each within the scatter of the next); then compound 2.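

In this assay, within the data shown here, the exchange of phenyl for methyl on this aromatic carbon, para to a large group, gives the first direct reading at this position: a number 3 percentage points higher from compound 1 to compound 4 (within the scatter) is the whole step, and no order can be read between the two compounds. For this pair, therefore, a substituent of six heavy atoms with a six-membered aromatic ring and one of a single carbon with no ring cannot be told apart by their maximal responses, so the second aromatic ring of compound 1 is not needed to hold the response at this level. No measurement at hand bears on why the step is so small.

Whether this position tolerates other groups equally remains open, as the compounds shown say nothing of a methoxy group, an amine, a carboxylic acid or a longer chain such as butyl at this carbon. Compound 2 differs from compound 4 in more than one place, so its higher number cannot be tied to any single change on the benzoate ring.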